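Triazolyl esters on the terpenoid acid core: compound 4

The source may hold more compounds than are shown below. What is called first, only, known or untested is meant among the compounds shown, and "the series" means these compounds.

Measured so far:
compound 2 `C#CCOC(=O)/C(C)=C/CC/C(C)=C/CC/C(C)=C/CC[C@@H]1[C@@]2(C)CCC(=O)C(C)(C)[C@H]2CC[C@@]1(C)O`: 46100 nM
compound 3 `C/C(=C\CC/C(C)=C/CC[C@@H]1[C@@]2(C)CCC(=O)C(C)(C)[C@H]2CC[C@@]1(C)O)CC/C=C(\C)C(=O)OCc1cn(-c2cccc(Cl)c2)nn1`: 103000 nM
compound 1 `C/C(=C\CC/C(C)=C/CC[C@@H]1[C@@]2(C)CCC(=O)C(C)(C)[C@H]2CC[C@@]1(C)O)CC/C=C(\C)C(=O)OCc1cn(-c2ccc(F)c(Cl)c2)nn1`: a limit only, > 150000 nM

In a functional assay on DU-145 cells (Homo sapiens) for antiproliferative activity, read by MTT assay, with a stated time of 48 h (on this read-out lower numbers stand for stronger inhibition and higher numbers for weaker inhibition), compound 2 stands lowest of the two numbers; its nearest neighbour is compound 3, with a 2.2-fold higher number from compound 2 to compound 3 (0.35 log units; beyond the scatter). Compound 1 gives only an assay limit, (the limit of > 150000 nM in this assay, at which 1 of the 3 values shown sits). Compound 4 `C/C(=C\CC/C(C)=C/CC[C@@H]1[C@@]2(C)CCC(=O)C(C)(C)[C@H]2CC[C@@]1(C)O)CC/C=C(\C)C(=O)OCc1cn(-c2cccc(O)c2)nn1` differs from compound 2 by 1-(3-hydroxyphenyl)-1H-1,2,3-triazol-4-yl in place of ethynyl on a saturated chain carbon bound to an oxygen next to a carbonyl group. The step that bears on it is a 2.2-fold higher number from compound 2 to compound 3 (0.35 log units; beyond the scatter), the same exchange with a chloro rather than a hydroxy group on the phenyl ring; an at least 1.4-fold lower number from compound 1 to compound 3 (0.16 log units; that floor lies within the scatter) shows a substituent change on that ring staying at or near the scatter. A modest rise is therefore expected, a 2.4-fold higher number from compound 2 to compound 4 (0.38 log units; beyond the scatter). Compound 4 is estimated at 110000 nM, between 50000 nM and 250000 nM.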

Compound 4, half-maximal inhibitory concentration: 28400 nM
Estimate against measurement, compound 4: 3.9-fold (0.59 log units) above; measured number outside the range, below it.
By their numbers in this assay, from the lowest: compounds 4 and 2 (each within the scatter of the next); then compound 3. At a limit, above all of these: compound 1.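

In this assay, the substituent on the phenyl ring of the triazolyl ester now makes a clear difference, with hydroxy in place of chloro giving a 3.6-fold lower number from compound 3 to compound 4 (0.56 log units; beyond the scatter). The exchange of ethynyl for 1-(3-hydroxyphenyl)-1H-1,2,3-triazol-4-yl gives a 1.6-fold lower number from compound 2 to compound 4 (0.21 log units; within the scatter), so this exchange need not cost activity when hydroxy is on the ring. The change from 3-chloro-4-fluorophenyl gives an at least 5.2-fold lower number from compound 1 to compound 4 (0.72 log units; beyond the scatter), and compound 1 stands only at a limit: the limit of > 150000 nM in this assay, at which 1 of the 4 values shown sits.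

From the compounds shown here alone, whether an amine or a carboxylic acid in place of hydroxy on the phenyl ring would match compound 4 remains open.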